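A second chloro on the terminal phenyl ring

The source may report more compounds than this note shows. Statements on the series, on what has been measured and on what is new or still open speak of the compounds shown alone.

Three compounds from one series are measured in a functional assay on MDA-MB-231 cells (Homo sapiens) for cytotoxicity, read by MTT assay, with a stated time of 72 h; on this read-out higher numbers stand for weaker inhibition and lower numbers for stronger inhibition. Compound 1, `CCN(CC)CCCNc1nc(-c2ccc(NC(=O)Nc3ccccc3)cc2)nc2c(Cl)c(Cl)sc12`, gives 1780 nM in this assay. Compound 2, `CCN(CC)CCCNc1nc(-c2ccc(NC(=O)Nc3ccccc3Cl)cc2)nc2c(Cl)c(Cl)sc12`, differs from compound 1 by chloro in place of hydrogen on an aromatic carbon. In this assay compound 2 gives 970 nM, a step of a 1.8-fold lower number from compound 1 to compound 2 (0.26 log units; within the scatter). Compound 3, `CCN(CC)CCNc1nc(-c2ccc(NC(=O)Nc3ccccc3Cl)cc2)nc2c(Cl)c(Cl)sc12`, differs from compound 2 by diethylamino in place of (diethylamino)methyl on a saturated chain carbon, two bonds along the chain from a nitrogen on an aromatic ring. In this assay compound 3 gives 1410 nM, a step of a 1.5-fold higher number from compound 2 to compound 3 (0.16 log units; within the scatter). The difference between the core of compound 1 and the core of compound 3 is not broken down here.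

Compound 4, `CCN(CC)CCNc1nc(-c2ccc(NC(=O)Nc3ccc(Cl)cc3Cl)cc2)nc2c(Cl)c(Cl)sc12`, is not yet measured. It differs from compound 3 by chloro in place of hydrogen on an aromatic carbon. Among the measured compounds shown here, this is the same kind of change as the one from compound 1 to compound 2, but not the same: there the chloro entered ortho to a large group, whereas here it enters meta to a chloro group and para to a large group.

For the measured compounds named here, the only guide to the step is the earlier one, and it is expected that compound 4 will show a step of a 1.4-fold lower number from compound 3 to compound 4 (0.15 log units; within the scatter) in this assay, resting on compound 1 to compound 2 having given a 1.8-fold lower number from compound 1 to compound 2 (0.26 log units; within the scatter). Compound 4 is therefore estimated at 1000 nM in this assay, with a range expected from 450 nM to 2500 nM.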

Compound 4, half-maximal inhibitory concentration: 1920 nM
For compound 4 the middle estimate is 1.9-fold (0.28 log units) below the measured one; the measured number falls inside the stated range.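

In this assay, going from 2-chlorophenyl to 2,4-dichlorophenyl gives a 1.4-fold higher number from compound 3 to compound 4 (0.13 log units; within the scatter), so on this core the added chloro has no effect that can be told apart from repeated-measurement noise. Set beside the earlier chloro step, this one cannot be separated from it, and the opposite directions of the two steps carry no weight on their own: the same change on two cores in this assay, a 1.8-fold lower number (0.26 log units; within the scatter) from compound 1 to compound 2 and a 1.4-fold higher number (0.13 log units; within the scatter) from compound 3 to compound 4, 2.5-fold (0.40 log units) apart, within the scatter of two such steps. This shows only that nothing here contradicts carrying the change from one core to the other; it does not show that the change carries over, since neither step stands clear of the scatter, the cores differ, and the chloro enters at a different place in each step.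

The compounds shown leave open whether any substituent on the terminal phenyl ring moves the number in this assay beyond the scatter, for instance a fluoro, a methoxy or a trifluoromethyl group, or a 4-chlorophenyl group without the 2-chloro. They also leave open how the 2,4-dichlorophenyl group behaves on the core of compound 2, and whether a longer chain or a cyclic amine such as piperidine or morpholine in place of the diethylamino group would give a step that can be read.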